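Adding a Methoxy Group Where Only a Halogen Swap Is Known

A few compounds are considered here, and "the series" means these few. Any claim that something is new, unique, unknown or untested is made for them only; others in the source may bear on it.

Measured so far:
Compound 1, `O=C/C=C/c1ccccc1OCc1cccc(Cl)c1`, gives 5900 nM in a functional assay on cells (Neutrophil, Rattus norvegicus, strain Sprague-Dawley) for inhibition; on this read-out higher numbers stand for weaker inhibition and lower numbers for stronger inhibition.
Compound 2, `O=C/C=C/c1ccccc1OCc1cccc(F)c1`, gives 4500 nM in this assay.

On these two numbers compound 1 holds the higher one, but the step of a 1.3-fold lower number from compound 1 to compound 2 (0.12 log units; within the scatter) lies within the scatter, so neither compound can be called stronger or weaker than the other. Compound 3, `COc1ccc(OCc2cccc(Cl)c2)c(/C=C/C=O)c1`, differs from compound 1 by methoxy in place of hydrogen on an aromatic carbon. Among the compounds with values here, no measured step concerns a methoxy entering the core; the only step available, from compound 1 to compound 2, exchanges one halogen for another and is itself within the scatter. It therefore offers no direction for the present change. In this assay compound 3 is expected to give a number close to that of compound 1, with no step beyond the scatter. The estimate for compound 3 is 5000 nM, within a range of 1500 nM to 15000 nM. This estimate corresponds to an expected step of a 1.2-fold lower number from compound 1 to compound 3 (0.07 log units; within the scatter).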

Compound 3, half-maximal inhibitory concentration: 4200 nM
Compound 3: the middle estimate sits 1.2-fold (0.08 log units) above what was measured; low and high end bracket the measured number.
By their numbers in this assay, from the lowest: compounds 3, 2 and 1 (each within the scatter of the next).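

Within the data shown here, the step of a 1.4-fold lower number from compound 1 to compound 3 (0.15 log units; within the scatter) in this assay is the first measured change on this aromatic carbon, meta to the 2-formylethenyl group and para to a group of 9 heavy atoms. The earlier pair had shown only a swap of one halogen for another at a different place, whereas this result shows that a methoxy can enter here without moving the number beyond the scatter. Nothing at hand bears on why this should be so.

The compounds shown leave open whether an amine, a carboxylic acid or a longer chain such as ethoxy on this carbon would move the number beyond the scatter. They also leave open whether methoxy gives a similar result on the core of compound 2, which carries fluoro in place of chloro.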